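The compounds below may be only part of what the source reports. "The series", "measured", "known", "first", "only" and "open" are said of these compounds alone.

Measured compounds:

- compound 1, `CCOC(=O)N(C)CC#CCN1CCCC1`: in a functional assay on the whole organism for agonist activity, with Mus musculus as the target (a lower number here means that less compound is needed, a higher number that more compound is needed for the effect), compound 1 gives > 100 mg/kg, a limit of the assay and not a number.
- compound 2, `CCOC(=O)N(C)CC#CCn1ccnc1`: in this assay compound 2 gives > 100 mg/kg, likewise a limit and not a number.
- compound 3, `CC(C#CCN1CCCC1)N1CCN(C)C1=O`: in this assay compound 3 gives > 30 mg/kg, also a limit and not a number.

None of the three measured compounds reaches a readable dose in this assay. Two of them sit at the limit of > 100 mg/kg in this assay, at which 2 of the 3 values shown sit, and the third sits at the limit of > 30 mg/kg in this assay, at which 1 of the 3 values shown sits.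

Among the compounds with values here, the one counted change between measured compounds is 1H-imidazol-1-yl in place of pyrrolidin-1-yl on a saturated chain carbon bound to a triple-bonded carbon, which gives a step that the two limits leave unreadable from compound 1 to compound 2. The difference between the core of compound 1 and the core of compound 3 is not broken down here.

Compound 4, `CC(C#CCn1ccnc1)N1CCN(C)C1=O`, is not yet measured in this assay. It differs from compound 3 by 1H-imidazol-1-yl in place of pyrrolidin-1-yl on a saturated chain carbon bound to a triple-bonded carbon, the same change as from compound 1 to compound 2, at the same place. As the step from compound 1 to compound 2 is not readable from the two limits, the expectation for compound 4 rests on compound 3 alone, which gives only > 30 mg/kg, a limit of the assay. The step from compound 3 to compound 4 in this assay is therefore expected to be close to a step that the limit leaves unreadable from compound 3 to compound 4, with no readable precedent for either direction. Compound 4 is expected to give about 100 mg/kg in this assay, most likely again reported only as a limit.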

Compound 4, dose for half-maximal effect: > 100 mg/kg
Compound 4: no number, only a limit (the forecaster's own chance of this, stated with the estimate: 80%); the middle value lies on the limit itself.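

In this assay compound 4 gives > 100 mg/kg, a limit of the assay and not a number. Compound 3 also gives only a limit, and the step between compound 3 and compound 4 cannot be read. The compounds shown leave open the size and direction of any shift in dose on replacing pyrrolidin-1-yl with 1H-imidazol-1-yl, as none of the four has a readable dose.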